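The compounds below may be only part of what the source reports. "The series", "measured", "known", "first", "only" and "open" are said of these compounds alone.

In a functional assay on HeLa cells (Homo sapiens) for antiproliferative activity, read by MTT assay, with a stated time of 48 h (on this read-out higher numbers stand for weaker inhibition and lower numbers for stronger inhibition), compound 1 `Cc1ccc(/C=N/c2ccccc2)c(C)c1` gives 33000 nM and compound 2 `O=[N+]([O-])c1ccc(/C=N/c2ccccc2)cc1` gives 123000 nM. Compound 2 therefore holds the higher of the two numbers, with a gap beyond the usual scatter. Compound 3 `FC(F)(F)c1ccc(/C=N/c2ccccc2)cc1` has trifluoromethyl in place of nitro on an aromatic carbon, para to a group of 8 heavy atoms: trifluoromethyl in place of nitro on an aromatic carbon. Among the measured compounds shown here, no measured pair shows this change, so only a modest shift toward a lower number is expected in this assay, though it may stay close to the scatter. The expected step is a 1.9-fold lower number from compound 2 to compound 3 (0.28 log units; within the scatter). For compound 3 the estimated value is 65000 nM, with an expected range from 22000 nM to 170000 nM.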

Compound 3, half-maximal inhibitory concentration: 900 nM
For compound 3 the middle estimate is 72-fold (1.86 log units) above the measured one; measured number below the stated range.
By their numbers in this assay, from the lowest: compound 3; then compound 1; then compound 2.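

In this assay, trifluoromethyl in place of nitro on an aromatic carbon, para to a group of 8 heavy atoms, gives a 140-fold lower number from compound 2 to compound 3 (2.14 log units; beyond the scatter). This single position is therefore far from indifferent: the read-out depends strongly on which of these two groups sits there. No measurement here explains the size of this step.

From the compounds shown here alone, whether an amine or a carboxylic acid at this position would give a number nearer that of compound 2 or that of compound 3 remains open. So does whether the same exchange would give a step of similar size elsewhere on the core.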